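From chloro to methylsulfonyl: a step starting from a limit

The source may hold more compounds than are shown below. What is called first, only, known or untested is meant among the compounds shown, and "the series" means these compounds.

For the measured compounds named here, in a toxicity assay on NIH3T3 cells (Mus musculus) for cytotoxicity, read by resazurin assay (on this read-out lower numbers stand for an effect already at smaller amounts and higher numbers for an effect only at larger amounts of compound), compound 1 (`COC(=O)c1ccc(NCc2cncn2Cc2ccc(Cl)cc2)cc1-c1ccccc1`) gives 25000 nM, the only actual number so far. Compound 2 (`Clc1ccc(Cn2cncc2CNc2ccc(-c3nc4ccccc4s3)c(-c3ccccc3)c2)cc1`) has only a limit, > 1000 nM, and no number of its own.

Compound 3 (`CS(=O)(=O)c1ccc(Cn2cncc2CNc2ccc(-c3nc4ccccc4s3)c(-c3ccccc3)c2)cc1`) differs from compound 2 in a single place: methylsulfonyl in place of chloro on an aromatic carbon. This is methylsulfonyl in place of chloro on an aromatic carbon, so that 4-chlorobenzyl becomes 4-(methylsulfonyl)benzyl.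

Going by the values given here, the one measured step, a step that the limit leaves unreadable from compound 1 to compound 2, concerns a different group, and no measured step covers this exchange. Nothing in hand therefore fixes a size or a direction for the change in this assay, and no definite shift either way is expected. The step can only be estimated loosely, as a step that the limit leaves unreadable from compound 2 to compound 3. Among the compounds with values here, the expectation leans on the sole number available, compound 1 at 25000 nM, and it is kept wide for that reason. For compound 3 the estimated value is 15000 nM, with an expected range from 3000 nM to 50000 nM.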

Compound 3, half-maximal effective concentration: > 1000 nM
Compound 3 gave a limit, no number; the forecaster's own chance of this, stated with the estimate: 35%; the middle value is on the limit's open side.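

In this assay, compound 2 and compound 3 each have only a limit and no number, so no step between them can be read: the limit of > 1000 nM in this assay, at which 2 of the 3 values shown sit.

Going by these compounds, whether methylsulfonyl in place of chloro on an aromatic carbon changes the result in this assay at all, and if so in which direction and by how much, stays open.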